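Swapping the 4-carboxyphenyl group of compound 3

The compounds below may be only part of what the source reports. "The series", "measured", "known", "first", "only" and "open" are said of these compounds alone.

Measured so far in a functional assay on ileum (Cavia porcellus) for antagonist activity; a lower number here means a stronger inhibitor, a higher number a weaker inhibitor
compound 1 `CC(=O)c1ccc(OCCCOc2ccc3c(O)c([N+](=O)[O-])c(=O)oc3c2)cc1` gives 6100 nM
compound 2 `O=C(O)c1ccc(OCCCOc2ccc3c(O)c([N+](=O)[O-])c(=O)oc3c2)cc1` gives > 20000 nM as a limit
compound 3 `O=C(O)c1ccc(OCC(O)COc2ccc3c(O)c([N+](=O)[O-])c(=O)oc3c2)cc1` gives > 10000 nM as a limit

Compound 3 has no exact number, only a limit (> 10000 nM). Compound 4 `CC(C)c1ccccc1OCC(O)COc1ccc2c(O)c([N+](=O)[O-])c(=O)oc2c1` carries 2-isopropylphenyl in place of 4-carboxyphenyl on an oxygen on a saturated carbon. The best guide is hydroxy in place of methyl on a carbonyl carbon, which gave an at least 3.2-fold higher number from compound 1 to compound 2 (0.51 log units; beyond the scatter) and created the carboxy group of the acids. The other measured step gives no size (a step that the two limits leave unreadable from compound 2 to compound 3). Removing the 4-carboxyphenyl group should therefore shift the result toward a lower number, meaning a stronger inhibitor, although this rests on one pair. In this assay the expected step is an at least 3.3-fold lower number from compound 3 to compound 4 (0.52 log units; beyond the scatter) in that direction. The estimate for compound 4 is 3000 nM (expected range 600 nM to 15000 nM).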

Compound 4, half-maximal inhibitory concentration: 160 nM
For compound 4 the middle estimate is 19-fold (1.27 log units) above the measured one; measured number below the stated range.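

In this assay, going by these compounds alone, the group on this oxygen matters far more than the earlier compounds could show: 2-isopropylphenyl in place of 4-carboxyphenyl gave an at least 62-fold lower number from compound 3 to compound 4 (1.79 log units; beyond the scatter). Compound 4 also shows that the chain carrying a hydroxy group does not by itself rule out strong inhibition. Compound 3 has only a limit, so the full size of this step stays unknown: the limit of > 10000 nM in this assay, at which 1 of the 4 values shown sits.

Still open, on these data alone, is whether losing the carboxy group or gaining the isopropyl group drives this change. A plain phenyl group on the same oxygen would help separate the two.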